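The source may report more compounds than this note shows. Statements on the series, on what has been measured and on what is new or still open speak of the compounds shown alone.

Measured compounds:
compound 1, `O=C(NCc1cc(Cl)ccc1-n1cnnn1)[C@@H]1[C@H]2C[C@H]2CN1C(=O)[C@H](O)CC1CC1`, in a functional assay on a cell-free system (plasma, Homo sapiens), with a stated time of 3 min (a lower number here means a stronger inhibitor, a higher number a weaker inhibitor), gives 1400 nM;
compound 2, `O=C(NCc1cc(Cl)ccc1-n1cnnn1)[C@@H]1[C@H]2C[C@H]2CN1C(=O)[C@H](O)c1ccccc1`, in this assay gives 960 nM;
compound 3, `CC(C)(C)OC[C@@H](O)C(=O)N1C[C@@H]2C[C@@H]2[C@H]1C(=O)NCc1cc(Cl)ccc1-n1cnnn1`, in this assay gives 570 nM.

Compound 3 holds the lowest of the three numbers, but its standing is mixed: the step of a 1.7-fold lower number from compound 2 to compound 3 (0.23 log units; within the scatter) lies within the scatter, whereas the step of a 2.5-fold lower number from compound 1 to compound 3 (0.39 log units; beyond the scatter) lies beyond it. The unmeasured compound 4, `O=C(NCc1cc(Cl)ccc1-n1cnnn1)[C@@H]1[C@H]2C[C@H]2CN1C(=O)[C@H](O)C1CCCCC1`, differs from compound 3 in one place: cyclohexyl in place of (tert-butoxy)methyl on a saturated chain carbon bound to a carbonyl carbon and an oxygen on a saturated carbon.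

Going by the values given here, two measured steps bear on this change. The step of a 1.7-fold lower number from compound 2 to compound 3 (0.23 log units; within the scatter) shows that a ring on this carbon and the (tert-butoxy)methyl group give numbers within the scatter of each other. The step of a 1.5-fold lower number from compound 1 to compound 2 (0.16 log units; within the scatter) shows that exchanging one carbon-only group for another on this carbon also stayed within the scatter. A cyclohexyl ring at the same place is therefore expected to give a number near that of compound 2, that is, a slightly higher number than compound 3, with the step of a 1.6-fold higher number from compound 3 to compound 4 (0.20 log units; within the scatter) expected to stay within or close to the scatter. Compound 4 is estimated at 900 nM, in the range 400 nM to 2000 nM.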

Compound 4, half-maximal inhibitory concentration: 850 nM
Beside the measured number, compound 4's estimate is 1.1-fold (0.02 log units) above it, within the range that was stated.
By their numbers in this assay, from the lowest: compounds 3, 4, 2 and 1 (each within the scatter of the next, the first and the last beyond it).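

Across the six heavy atoms of each group, the cyclohexyl ring gives no separation from phenyl on this carbon, with a 1.1-fold lower number from compound 2 to compound 4 (0.05 log units; within the scatter) in this assay, so a carbon-only ring and phenyl cannot be told apart here. The oxygen of the (tert-butoxy)methyl group also brings no separation from cyclohexyl, with a 1.5-fold higher number from compound 3 to compound 4 (0.17 log units; within the scatter), while a 1.6-fold lower number from compound 1 to compound 4 (0.22 log units; within the scatter) stays within the scatter, unlike a 2.5-fold lower number from compound 1 to compound 3 (0.39 log units; beyond the scatter), so only compound 3 is separated from compound 1. No other measurement is at hand to account for these numbers.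

From the compounds shown here alone, whether an amine or a carboxylic acid on this carbon, or a longer chain, would leave this narrow band remains open. The hydroxyl group on this carbon is common to all four compounds, so its own contribution cannot be judged from them.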